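Dimethylamino in place of piperidin-1-yl on the chain

This account rests on a few compounds, and the source may have more. Where it says the series, first, only, none or still open, it means among the compounds named here.

Compound 1 `Cn1ncc(Cl)c1-c1cc(C(=O)N[C@@H]2CN[C@H](CCCO)C[C@H]2c2ccc(Cl)c(Cl)c2)oc1Cl`: 600 nM
Compound 2 `Cn1ncc(Cl)c1-c1cc(C(=O)N[C@@H]2CN[C@H](CCn3cncn3)C[C@H]2c2ccc(Cl)c(Cl)c2)oc1Cl`: 1560 nM
Compound 3 `Cn1ncc(Cl)c1-c1cc(C(=O)N[C@@H]2CN[C@H](CCN3CCCCC3)C[C@H]2c2ccc(Cl)c(Cl)c2)oc1Cl`: 1660 nM

In a functional assay on OVCAR-8 cells (Homo sapiens) for antiproliferative activity (a higher number here means a weaker inhibitor, a lower number a stronger inhibitor), compound 3 stands with compound 2 at the upper end of the numbers, and compound 1 lies clearly lower. Compound 4 `CN(C)CC[C@@H]1C[C@@H](c2ccc(Cl)c(Cl)c2)[C@H](NC(=O)c2cc(-c3c(Cl)cnn3C)c(Cl)o2)CN1` carries dimethylamino in place of piperidin-1-yl on a saturated chain carbon, two bonds along the chain from a saturated ring carbon. Exchanges at this place have so far given modest steps, a 2.6-fold higher number from compound 1 to compound 2 (0.41 log units; beyond the scatter) and a 2.8-fold higher number from compound 1 to compound 3 (0.44 log units; beyond the scatter). Exchanging 1H-1,2,4-triazol-1-yl for piperidin-1-yl gave a 1.1-fold higher number from compound 2 to compound 3 (0.03 log units; within the scatter). No step beyond the scatter is therefore expected in this assay. The estimated step is a 1.1-fold lower number from compound 3 to compound 4 (0.04 log units; within the scatter). For compound 4 the expected value is 1500 nM, with an estimated range of 700 nM to 3000 nM.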

Compound 4, half-maximal inhibitory concentration: 1510 nM
Beside the measured number, compound 4's estimate is 1.0-fold (0.00 log units) below it, within the range that was stated.
By their numbers in this assay, from the lowest: compound 1; then compounds 4, 2 and 3 (each within the scatter of the next).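

In this assay, dimethylamino, which has no ring, gives the same result as piperidin-1-yl, a 1.1-fold lower number from compound 3 to compound 4 (0.04 log units; within the scatter), and as 1H-1,2,4-triazol-1-yl, a 1.0-fold lower number from compound 2 to compound 4 (0.01 log units; within the scatter). Compound 1 remains apart, a 2.5-fold higher number from compound 1 to compound 4 (0.40 log units; beyond the scatter), so among these four compounds only the one with hydroxymethyl differs beyond the scatter. Nothing measured here offers an explanation for this. From the compounds shown here alone, it remains open whether a primary amine, a carboxylic acid or a longer chain at this place would group with compound 1 or with compound 2, compound 3 and compound 4.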